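Trimming the Amide and Adding a Hydroxyl: Compound 4

A few compounds are considered here, and "the series" means these few. Any claim that something is new, unique, unknown or untested is made for them only; others in the source may bear on it.

Measured so far:
compound 1 `Cc1cc(C(=O)N2CCCCc3ccccc32)ccc1CNC(=O)NCC(=O)O` gives 180 nM
compound 2 `Cc1cc(C(=O)N2CCCCc3ccccc32)ccc1CNC(=O)N1CCC[C@H]1C(=O)OC(C)C` gives 950 nM
compound 3 `CCN(CC)C(=O)[C@@H]1CCCN1C(=O)NCc1ccc(C(=O)N2CCCCc3ccccc32)cc1C` gives 350 nM

In a functional assay on HEK293 cells for agonist activity at Vasopressin V2 receptor (Homo sapiens), read by a luciferase reporter and cAMP accumulation (a higher number here means that more compound is needed for the effect, a lower number that less compound is needed), compound 3 stands second highest of the three, close to compound 1 and separated from compound 2 by a 2.7-fold lower number from compound 2 to compound 3 (0.43 log units; beyond the scatter), which is modest. Compound 4 `Cc1cc(C(=O)N2CCCCc3ccccc32)ccc1CNC(=O)N1C[C@H](O)C[C@H]1C(=O)N(C)C` differs from compound 3 by 2-(dimethylcarbamoyl)-4-hydroxypyrrolidin-1-yl in place of 2-(diethylcarbamoyl)pyrrolidin-1-yl on a carbonyl carbon. Within the data shown here, no measured step probes either the shorter amide substituents or the added hydroxyl directly; the closest comparison, a 2.7-fold lower number from compound 2 to compound 3 (0.43 log units; beyond the scatter), changed only the group on that carbonyl and moved the number modestly, while a 1.9-fold higher number from compound 1 to compound 3 (0.29 log units; within the scatter) stayed within the scatter. A small shift is therefore expected, direction uncertain, so compound 4 is estimated at 400 nM (range 130 nM to 1200 nM), meaning an expected step of a 1.1-fold higher number from compound 3 to compound 4 (0.06 log units; within the scatter).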

Compound 4, half-maximal effective concentration: 2.3 nM
For compound 4 the middle estimate is 170-fold (2.24 log units) above the measured one; measured number outside the range, below it.
By their numbers in this assay, from the lowest: compound 4; then compounds 1 and 3 (each within the scatter of the next); then compound 2.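

Earlier changes to the group on this carbonyl carbon moved the number only modestly, but in this assay 2-(dimethylcarbamoyl)-4-hydroxypyrrolidin-1-yl brings a 150-fold lower number from compound 3 to compound 4 (2.18 log units; beyond the scatter) and a 410-fold lower number from compound 2 to compound 4 (2.62 log units; beyond the scatter) and a 78-fold lower number from compound 1 to compound 4 (1.89 log units; beyond the scatter). Among these compounds, this place can therefore respond far more strongly than the earlier compounds showed. Nothing available explains the gain. The new group has both shorter amide substituents and a hydroxyl, so the compounds shown cannot say which of these matters. A methoxy in place of that hydroxyl would also test whether its hydrogen is needed.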